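A few compounds are considered here, and "the series" means these few. Any claim that something is new, unique, unknown or untested is made for them only; others in the source may bear on it.

Values in a functional assay on KB cells (Homo sapiens) for cytotoxicity, read by resazurin assay, with a stated time of 3 days (on this read-out lower numbers stand for stronger inhibition and higher numbers for weaker inhibition), so far:
compound 1 (`CC(C)(CNC(=O)c1ccc2ccccc2c1)CC1=C(O)C(=O)c2ccccc2C1=O`) gives 9000 nM
compound 2 (`COc1c(C(=O)NCC(C)(C)CC2=C(O)C(=O)c3ccccc3C2=O)ccc2ccccc12`) gives 66900 nM
compound 3 (`COc1ccc(OC)c(C(=O)NCC(C)(C)CC2=C(O)C(=O)c3ccccc3C2=O)c1`) has not yet been measured

Compound 1 holds the lower of the two numbers, and compound 2 is its nearest neighbour. The change from compound 1 to compound 3 is 2,5-dimethoxyphenyl in place of naphthalen-2-yl on a carbonyl carbon.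

For the measured compounds named here, only one measured step bears on this change: methoxy in place of hydrogen on an aromatic carbon, which gives a 7.4-fold higher number from compound 1 to compound 2 (0.87 log units; beyond the scatter) (modest, and beyond the scatter). The match is partial, since compound 3 replaces the whole group on the carbonyl carbon. Going by the values given here, no measured compound shows what leaving naphthalen-2-yl does on its own. In this assay a modest step toward a higher number is therefore expected, though one within the scatter remains possible. The expected change is a 2.8-fold higher number from compound 1 to compound 3 (0.44 log units; beyond the scatter) (an estimate resting on a single step). For compound 3 the estimated value is 25000 nM (expected range 7000 nM to 80000 nM).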

Compound 3, half-maximal inhibitory concentration: 86600 nM
Compound 3: middle estimate off by 3.5-fold (0.54 log units), on the low side, and the stated range ends below it.
By their numbers in this assay, from the lowest: compound 1; then compounds 2 and 3 (each within the scatter of the next).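

In this assay, a 9.6-fold higher number from compound 1 to compound 3 (0.98 log units; beyond the scatter), so a second replacement at the carbonyl carbon also moves beyond the scatter, this time with naphthalen-2-yl gone altogether rather than carrying an added methoxy. Compound 2 and compound 3 stand within the scatter of each other, so in these three compounds the two different changes end at about the same level, and compound 1 alone keeps the lowest number. No measurement available for the series explains the step from the unsubstituted naphthalen-2-yl group to 2,5-dimethoxyphenyl.

Compound 3 changes the ring system and brings in both methoxy groups in a single step, so the shares of leaving naphthalen-2-yl and of adding methoxy cannot be separated here. Unsubstituted phenyl, phenyl with a single methoxy, and naphthalen-2-yl bearing an amine or a carboxylic acid would be needed to tell whether the low number of compound 1 depends on the bare naphthalen-2-yl group or tolerates other substituents at this position.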